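The source may report more compounds than this note shows. Statements on the series, on what has been measured and on what is new or still open speak of the compounds shown alone.

Measured in an ADME assay on HEK293 cells (Homo sapiens) for cytotoxicity, read by MTT assay, with a stated time of 24 h; on this read-out lower numbers stand for stronger inhibition and higher numbers for weaker inhibition:
- Compound 1 `CN(C)CCCNc1nc2cc([N+](=O)[O-])ccc2nc1NCc1ccc(C(F)(F)F)cc1`: 5.66 ug/mL
- Compound 2 `CN(C)CCCCNc1nc2cc([N+](=O)[O-])ccc2nc1NCc1ccc(C(F)(F)F)cc1`: 9.73 ug/mL
- Compound 3 `O=[N+]([O-])c1ccc2nc(NCc3ccc(C(F)(F)F)cc3)c(N3CCCCC3)nc2c1`: > 200 ug/mL (a limit, not a number)

Compound 3 stands apart from the other two. Among the measured compounds shown here, its entry of > 200 ug/mL is a limit of this assay, and it is the only one of the three values that is not a number.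

The next compound, compound 4 `CN1CCN(c2nc3cc([N+](=O)[O-])ccc3nc2NCc2ccc(C(F)(F)F)cc2)CC1`, puts 4-methylpiperazin-1-yl in place of piperidin-1-yl on an aromatic carbon.

For the measured compounds named here, no measured step makes this ring-for-ring exchange. The nearest evidence is an at least 35-fold higher number from compound 1 to compound 3 (1.54 log units; beyond the scatter) and an at least 20-fold higher number from compound 2 to compound 3 (1.31 log units; beyond the scatter). Both are large, and both bring in piperidin-1-yl in place of an open chain ending in dimethylamino. The step between those two chains, a 1.7-fold higher number from compound 1 to compound 2 (0.24 log units; within the scatter), lies within the scatter.

Compound 4 keeps a six-membered non-aromatic ring, as compound 3 does, so a return all the way to the level of compound 1 at 5.66 ug/mL is not expected. Its ring does gain a second nitrogen, carrying a methyl group, so some move towards a lower number is expected, though it may be modest and compound 4 could again return only a limit. The expected change is an at least 2.8-fold lower number from compound 3 to compound 4 (0.45 log units; beyond the scatter).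

For compound 4 the estimate is 70 ug/mL, with an expected range from 20 ug/mL to 200 ug/mL.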

Compound 4, half-maximal inhibitory concentration: 6.99 ug/mL
Estimate against measurement, compound 4: 10-fold (1.00 log units) above, outside the stated range (below it).
By their numbers in this assay, from the lowest: compounds 1, 4 and 2 (each within the scatter of the next). At a limit, above all of these: compound 3.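

In this assay, the step of an at least 28-fold lower number from compound 3 to compound 4 (1.45 log units; beyond the scatter) shows that this position, on an aromatic carbon next to the ring nitrogen, can hold a six-membered non-aromatic ring and still give a number as low as those of the open-chain compounds, and that a ring carbon exchanged for a nitrogen carrying a methyl group is enough to make that difference. Exchanging either open chain for 4-methylpiperazin-1-yl makes no change that can be told from the scatter, as the steps of a 1.4-fold lower number from compound 2 to compound 4 (0.14 log units; within the scatter) and a 1.2-fold higher number from compound 1 to compound 4 (0.09 log units; within the scatter) show, so an open chain ending in dimethylamino is not needed for a low number here. The size of the large step stays a bound, as compound 3 stands at a limit and not at a number: the limit of > 200 ug/mL in this assay, at which 1 of the 4 values shown sits.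

The compounds shown leave open whether the second ring nitrogen alone accounts for the step or its methyl group takes part, which a piperazin-1-yl ring with a free amine or a morpholin-4-yl ring would help to separate. They also leave open how a larger group on that nitrogen, such as an ethyl or an acetyl, would read in this assay.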